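Removing One Methoxy from Compound 1

This account rests on a few compounds, and the source may have more. Where it says the series, first, only, none or still open, it means among the compounds named here.

The set holds three measured compounds: compound 1 `COc1ccc(/C=C/c2cc(C)no2)cc1OC`, compound 2 `CC(=O)/C=C(O)/C=C/c1ccc(O)c(O)c1` and compound 3 `COc1ccc(/C=C/C(=O)CC(C)=O)cc1OC`, all examined in a functional assay on MCF7 cells (Homo sapiens) for cytotoxicity, read by MTT assay, with a stated time of 72 h; a lower number here means a stronger inhibitor, a higher number a weaker inhibitor. For compound 1 the assay reports only a limit, > 100000 nM, as noted in the limit of > 100000 nM in this assay, at which 1 of the 3 values shown sits. Compound 2 gives 7900 nM and compound 3 gives 10600 nM. Going by the values given here, the one measured single-place step, an at least 9.4-fold lower number from compound 1 to compound 3 (0.97 log units; beyond the scatter), alters the chain end rather than the six-membered aromatic ring. Compound 4 `COc1ccc(/C=C/c2cc(C)no2)cc1` differs from compound 1 by hydrogen in place of methoxy on an aromatic carbon. Among the compounds with values here, no measured step touches that position, so no shift beyond the scatter is expected, and compound 4 is expected to stay at or near the limit, with an estimated value of 150000 nM between 50000 nM and 500000 nM. The expected step is a step that the limit leaves unreadable from compound 1 to compound 4.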

Compound 4, half-maximal inhibitory concentration: > 100000 nM
Compound 4 was reported as a limit (the forecaster's own chance of this, stated with the estimate: 80%); the middle value does not contradict the limit.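

Going by these compounds alone, compound 1 and compound 4 both stand only as limits in this assay, so no step between them can be read. On these data alone, whether hydrogen in place of methoxy on an aromatic carbon shifts cytotoxicity at all remains open.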